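A few compounds are considered here, and "the series" means these few. Any claim that something is new, unique, unknown or untested is made for them only; others in the source may bear on it.

Measured in a functional assay on DU-145 cells (Homo sapiens) for antiproliferative activity, read by MTT assay, with a stated time of 48 h; a higher number here means a weaker inhibitor, a lower number a stronger inhibitor:

- compound 1 `Cc1cccn2cc(-c3nnc(-c4ccc(Br)cc4)o3)nc12`: 38900 nM
- compound 2 `Cc1cc(Br)c2nc(-c3nnc(-c4ccccc4)o3)cn2c1`: 18900 nM
- compound 3 `Cc1cc(Br)c2nc(-c3nnc(-c4ccc(Cl)cc4)o3)cn2c1`: 46000 nM

Compound 3 lies within the scatter of compound 1 and beyond the scatter of compound 2, so it belongs to the weaker end of this small set. Compound 4 `Cc1cc(Br)c2nc(-c3nnc(-c4ccc(Br)cc4)o3)cn2c1` differs from compound 3 in one place: bromo in place of chloro on an aromatic carbon. This is bromo in place of chloro on an aromatic carbon, turning 4-chlorophenyl into 4-bromophenyl.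

Going by the values given here, no measured step covers this exchange directly. The nearest evidence is a 2.4-fold higher number from compound 2 to compound 3 (0.39 log units; beyond the scatter), a modest change for chloro in place of hydrogen at the same place. Compound 1 also carries 4-bromophenyl, though on a different core, and its value of 38900 nM lies close to that of compound 3. Neither observation points to a large shift in this assay. The estimated step is a 1.1-fold lower number from compound 3 to compound 4 (0.04 log units; within the scatter), and no change beyond the scatter is expected. For compound 4 the estimated value is 42000 nM, with an expected range of 21000 nM to 85000 nM.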

Compound 4, half-maximal inhibitory concentration: 22300 nM
Compound 4: the middle estimate sits 1.9-fold (0.27 log units) above what was measured, and the stated range covers the measured number.
By their numbers in this assay, from the lowest: compounds 2, 4, 1 and 3 (each within the scatter of the next, the first and the last beyond it).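

In this assay the exchange of 4-chlorophenyl for 4-bromophenyl does change the reading, with a 2.1-fold lower number from compound 3 to compound 4 (0.31 log units; beyond the scatter), so the two halogens do not behave alike at this place. Bromo in place of hydrogen gives a 1.2-fold higher number from compound 2 to compound 4 (0.07 log units; within the scatter), whereas chloro in place of hydrogen gives a 2.4-fold higher number from compound 2 to compound 3 (0.39 log units; beyond the scatter), so on this core only chloro moves the number beyond the scatter from the unsubstituted phenyl. Nothing available explains why these two halogens part in this way.

From the compounds shown here alone, whether fluoro, methoxy or an amine at this place would follow bromo or chloro remains open. The compounds shown also leave open whether the difference between chloro and bromo would hold on a different core or in other cells.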